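Swapping the aryl group on the ring amine nitrogen

This account rests on a few compounds, and the source may have more. Where it says the series, first, only, none or still open, it means among the compounds named here.

Measured so far in a functional assay on HeLa cells (Homo sapiens) for antiproliferative activity, read by MTT assay, with a stated time of 48 h; a lower number here means a stronger inhibitor, a higher number a weaker inhibitor:
Compound 1 `Cc1ccc(N2CCN(Cn3nc(-c4ccc5c(c4)OCCO5)oc3=S)CC2)c(C)c1` gives only a limit, > 50000 nM.
Compound 2 `Fc1ccccc1N1CCN(Cn2nc(-c3ccc4c(c3)OCCO4)oc2=S)CC1` gives 37300 nM.
Compound 3 `Fc1ccc(N2CCN(Cn3nc(-c4ccc5c(c4)OCCO5)oc3=S)CC2)cc1` gives only a limit, > 50000 nM.

Compound 3 thus sits at the limit of this assay (the limit of > 50000 nM in this assay, at which 2 of the 3 values shown sit). Compound 4 `S=c1oc(-c2ccc3c(c2)OCCO3)nn1CN1CCN(c2ccccc2Cl)CC1` differs from compound 3 by 2-chlorophenyl in place of 4-fluorophenyl on an amine nitrogen in a ring. The closest guide is an at least 1.3-fold higher number from compound 2 to compound 3 (0.12 log units; that floor lies within the scatter), which points to a slightly lower number for the new compound, and an at least 1.3-fold lower number from compound 1 to compound 2 (0.12 log units; that floor lies within the scatter) runs the same way, while a step that the two limits leave unreadable from compound 1 to compound 3 stays unreadable. All measured steps are small, so no shift beyond the scatter is expected. A step of an at least 1.1-fold lower number from compound 3 to compound 4 (0.07 log units; that floor lies within the scatter) is estimated for compound 4. Compound 4 is therefore expected near 42000 nM, between 18000 nM and 100000 nM, with a real chance that only a limit is reported again.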

Compound 4, half-maximal inhibitory concentration: 37400 nM
For compound 4 the middle estimate is 1.1-fold (0.05 log units) above the measured one; measured number inside the range.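

Chloro in place of fluoro on the aromatic carbon gives a 1.0-fold higher number from compound 2 to compound 4 (0.00 log units; within the scatter), the first step here with a measured number at both ends, and it shows no change beyond the scatter. The steps of an at least 1.3-fold lower number from compound 3 to compound 4 (0.12 log units; that floor lies within the scatter) and an at least 1.3-fold lower number from compound 1 to compound 4 (0.12 log units; that floor lies within the scatter) remain floors because one end of each is a limit rather than a number: the limit of > 50000 nM in this assay, at which 2 of the 4 values shown sit.

The compounds shown leave open whether a methoxy group or a nitrile on the phenyl ring, or a pyridine ring in its place, would move the number beyond the scatter.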